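A few compounds are considered here, and "the series" means these few. Any claim that something is new, unique, unknown or untested is made for them only; others in the source may bear on it.

In a functional assay on L1210 cells (Mus musculus) for inhibition (a lower number here means a stronger inhibitor, a higher number a weaker inhibitor), compound 1 `C#CCN(Cc1ccc2nc(C)nc(O)c2c1)c1ccc(C#N)cc1` gives > 5000 nM, which is a limit of the assay and not a number. Compound 2 `C#CCN(Cc1ccc2nc(C)nc(O)c2c1)c1ccc(C(=O)c2ccccc2)cc1` gives 7700 nM, and compound 3 `C#CCN(Cc1ccc2nc(C)nc(O)c2c1)c1ccc(S(=O)(=O)N2CCOCC2)cc1` gives 3100 nM, the lower of the two actual numbers. Compound 4 `C#CCN(Cc1ccc2nc(C)nc(O)c2c1)c1ccc(S(=O)(=O)N2CCNCC2)cc1` differs from compound 3 on a sulfonyl sulfur, with piperazin-1-yl in place of morpholin-4-yl on a sulfonyl sulfur. Within the data shown here, no measured step makes this exchange. The nearest evidence comes from changes of the whole group on an aromatic carbon, which gave a 2.5-fold lower number from compound 2 to compound 3 (0.40 log units; beyond the scatter) and an at least 1.6-fold lower number from compound 1 to compound 3 (0.20 log units; that floor lies within the scatter). Given those modest steps, no change beyond the scatter is expected for this smaller exchange. The expected step is a 1.0-fold lower number from compound 3 to compound 4 (0.01 log units; within the scatter). Compound 4 is estimated at 3000 nM, within an expected range of 1100 nM to 8000 nM.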

Compound 4, half-maximal inhibitory concentration: > 50000 nM
Compound 4: only a limit was reported; the forecaster's own chance of this, stated with the estimate: 15%; middle value at least 16-fold (1.22 log units) from the limit.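

In this assay, among these compounds, the group on the sulfonyl sulfur matters far more than the earlier steps suggested: piperazin-1-yl in place of morpholin-4-yl gives an at least 16-fold higher number from compound 3 to compound 4 (1.20 log units; beyond the scatter). The sulfonyl link alone therefore does not set the number, since (morpholin-4-yl)sulfonyl improves on benzoyl but (piperazin-1-yl)sulfonyl gives an at least 6.4-fold higher number from compound 2 to compound 4 (0.81 log units; beyond the scatter), while the step involving the two limits cannot be read. The value of compound 4 is a limit and not a number: the limit of > 50000 nM in this assay, at which 1 of the 4 values shown sits.

Going by these compounds, whether piperidin-1-yl or dimethylamino on the sulfonyl sulfur would stay near compound 3 or fall with compound 4 remains open.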